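Carbamate in Place of Trifluoromethyl on a Shared Core

A few compounds are considered here, and "the series" means these few. Any claim that something is new, unique, unknown or untested is made for them only; others in the source may bear on it.

The series shares one core, carrying a substituted benzylamine arm. In an assay for inhibition of Tryptophan 2,3-dioxygenase (Homo sapiens), with a stated time of 1 h, tested at 10 uM (a higher number here means more inhibition at the concentration tested (going by the name of the read-out), a lower number less inhibition), compound 1 `Nc1cccc(CNc2cc(Br)cc3[nH]ncc23)c1` gives "not active" (no number reported). Compound 2 `ONc1cccc(CNc2cc(Br)cc3[nH]ncc23)c1` gives "not active" (no number reported) in this assay. For the measured compounds named here, compound 3 `FC(F)(F)c1cccc(CNc2cc(Br)cc3[nH]ncc23)c1` gives 56% in this assay, and it is the only compound of the three with a reported number; the other two entries carry none. Compound 4 `CCOC(=O)Nc1cccc(CNc2cc(Br)cc3[nH]ncc23)c1` differs from compound 3 as follows: (ethoxycarbonyl)amino in place of trifluoromethyl on an aromatic carbon. Since compound 1 and compound 2, which also carry a nitrogen-bearing group at this position, are reported as not active in this assay, a step downward beyond the scatter is expected from compound 3 to compound 4, estimated as a number 28 percentage points lower from compound 3 to compound 4 (beyond the scatter). Compound 4 is expected to give about 28% in this assay, within a range from 5% to 55%.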

Compound 4, a percentage reported as inhibition, at one concentration (the size of the read-out at that concentration, not a potency): "not active" (no number reported)
No number was reported for compound 4, so the estimate cannot be set against anything.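

For the compounds shown here, with no number reported for compound 4, no step from compound 3 to compound 4 can be read. Nothing measured here bears on a cause for this result. The compounds shown leave open whether any group other than trifluoromethyl at this place gives a numerical reading.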